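A few compounds are considered here, and "the series" means these few. Any claim that something is new, unique, unknown or untested is made for them only; others in the source may bear on it.

Compound 3 `CCCCCCCCCCn1cc(/C=C/C(=O)c2ccc(NC(=O)CN3CCN(c4ccc([N+](=O)[O-])cc4)CC3)cc2)nn1` is one of three compounds tested in a functional assay on SK-N-SH cells (Homo sapiens) for inhibition, read by MTT assay (a lower number here means a stronger inhibitor, a higher number a weaker inhibitor), where compound 3 gives 40900 nM. The other two are compound 1 `CCCCCCCCCCn1cc(/C=C/C(=O)c2ccc(NC(=O)CN3CCN(c4ccccc4)CC3)cc2)nn1`, which in this assay gives 39500 nM, and compound 2 `COc1ccccc1N1CCN(CC(=O)Nc2ccc(C(=O)/C=C/c3cn(Cc4ccc(Br)cc4)nn3)cc2)CC1`, which in this assay gives 28000 nM. Compound 3 has the highest of the three numbers, but its distances to compound 1 and to compound 2 both fall within the scatter, so no order among them can be read. The step to compound 4 `CCCCCCCCCCn1cc(/C=C/C(=O)c2ccc(NC(=O)CN3CCN(c4ccccc4OC)CC3)cc2)nn1` is 2-methoxyphenyl in place of 4-nitrophenyl on an amine nitrogen in a ring. Within the data shown here, the one measured step at the same ring, a 1.0-fold higher number from compound 1 to compound 3 (0.02 log units; within the scatter), lies within the scatter. Compound 2 carries the same 2-methoxyphenyl group but differs elsewhere from compound 4, and its number sits close to the others. On that basis no change beyond the scatter is expected, so the step of a 1.2-fold lower number from compound 3 to compound 4 (0.07 log units; within the scatter) is estimated to be small. Compound 4 is therefore expected to give about 35000 nM in this assay, within a range from 18000 nM to 70000 nM.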

Compound 4, half-maximal inhibitory concentration: 87600 nM
The estimate for compound 4 lay 2.5-fold (0.40 log units) below the measured number, outside the stated range (above it).
By their numbers in this assay, from the lowest: compounds 2, 1 and 3 (each within the scatter of the next); then compound 4.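

In this assay, 2-methoxyphenyl in place of 4-nitrophenyl on the ring amine nitrogen gave a 2.1-fold higher number from compound 3 to compound 4 (0.33 log units; beyond the scatter), and the methoxy group set against the unsubstituted phenyl gave a 2.2-fold higher number from compound 1 to compound 4 (0.35 log units; beyond the scatter). This shows that this position can move the number beyond the scatter, which the nitro step, a 1.0-fold higher number from compound 1 to compound 3 (0.02 log units; within the scatter), had not shown, and that the move was towards a weaker inhibitor. With 2-methoxyphenyl kept, nonyl in place of 4-bromophenyl gave a 3.1-fold higher number from compound 2 to compound 4 (0.50 log units; beyond the scatter), so the group at the far end of the molecule also counts once this aryl group is present.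

Nothing shown here explains why the methoxy group raises the number. As far as these compounds go, it also stays open whether 4-methoxyphenyl or 2-hydroxyphenyl on the same nitrogen would follow 2-methoxyphenyl or stay with unsubstituted phenyl.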